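Methyl Added to the Pyrazole of Compound 3

A few compounds are considered here, and "the series" means these few. Any claim that something is new, unique, unknown or untested is made for them only; others in the source may bear on it.

Of the compounds shown here, three built on one shared core have been tested in an ADME assay on microsomes from liver (Homo sapiens) for metabolic stability; a higher number here means faster removal of the compound, a lower number slower removal. Compound 1 `CCCC(Oc1ccc(-n2cc(Cl)cn2)cc1)c1ccc(C(=O)NCCC(=O)O)cc1` gives 10 mL/min/kg. Compound 3 `CCCC(Oc1ccc(-n2cc(C(F)(F)F)cn2)cc1)c1ccc(C(=O)NCCC(=O)O)cc1` gives 16 mL/min/kg. For compound 2 `CCCC(Oc1ccc(-n2cc(C(=O)N(C)C)cn2)cc1)c1ccc(C(=O)NCCC(=O)O)cc1` this assay reports only a limit, < 13 mL/min/kg, so no number is known for it (the limit of < 13 mL/min/kg in this assay, at which 1 of the 3 values shown sits). Compound 3 stands at the top of the two plain numbers shown, yet the step of a 1.6-fold higher number from compound 1 to compound 3 (0.20 log units; within the scatter) lies within the scatter, so the two cannot really be told apart. The step that the limit leaves unreadable from compound 1 to compound 2 is not readable, and the step of an at least 1.2-fold higher number from compound 2 to compound 3 (0.09 log units; that floor lies within the scatter) has a floor that also lies within the scatter.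

Compound 4 `CCCC(Oc1ccc(-n2cc(C(F)(F)F)c(C)n2)cc1)c1ccc(C(=O)NCCC(=O)O)cc1` has not yet been measured. It differs from compound 3 in one place: methyl in place of hydrogen on an aromatic carbon. Within the data shown here, none of the measured steps touches this part of the molecule; all three exchange chloro, trifluoromethyl and dimethylcarbamoyl on another aromatic carbon, and each of them is either unreadable or within the scatter. No step beyond the scatter is therefore expected in this assay for compound 4, and the estimated step of a 1.1-fold higher number from compound 3 to compound 4 (0.05 log units; within the scatter) is small. The clearance of compound 4 is estimated at 18 mL/min/kg, with a likely range from 9 mL/min/kg to 36 mL/min/kg.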

Compound 4, clearance: < 10 mL/min/kg
Compound 4: only a limit was reported; the forecaster's own chance of this, stated with the estimate: 10%; middle value at least 1.8-fold (0.25 log units) from the limit.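

Among these compounds, compound 4 has only a limit in this assay (< 10 mL/min/kg), and this is the first look at this carbon of the pyrazole, because all the earlier steps exchanged groups on another aromatic carbon: the limit of < 10 mL/min/kg in this assay, at which 1 of the 4 values shown sits. Methyl in place of hydrogen here, next to the ring nitrogen and next to the ring atom that bears a trifluoromethyl group, gives an at least 1.6-fold lower number from compound 3 to compound 4 (0.20 log units; that floor lies within the scatter) and so shows no rise in clearance, though its floor alone cannot show a real fall. The data also give a number no higher from compound 1 to compound 4 (the limit leaves the size open) and the step to compound 4 from compound 2 cannot be read.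

The limit leaves open how far the clearance of compound 4 really lies from that of compound 3, and so whether this step passes the scatter at all. The compounds shown hold only hydrogen or methyl at this carbon, and methyl only alongside trifluoromethyl, so nothing here tells how an ethyl group, a methoxy group or an amine would read there, or how methyl would read alongside chloro.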